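Varying the sulfamoyl amine on a piperidine sulfonamide core

A few compounds are considered here, and "the series" means these few. Any claim that something is new, unique, unknown or untested is made for them only; others in the source may bear on it.

Compound 3 `CC(C)NS(=O)(=O)c1ccc(S(=O)(=O)N2CCC[C@@H](C(=O)N3CCN(c4nc(C(C)C)no4)CC3)C2)cc1` gives 0.489 h in an ADME assay on microsomes from liver (Mus musculus) for metabolic stability, read by LC-MS, with a stated time of 60 min, tested at 10 uM (a higher number here means that the compound lasts longer, a lower number that the compound disappears faster), the higher of the two plain numbers available. Compound 1 `CCN(CC)C(=O)c1ccc(S(=O)(=O)N2CCC[C@@H](C(=O)N3CCN(c4nc(C(C)C)no4)CC3)C2)cc1` gives 0.175 h in this assay. Compound 2 `CC(C)c1noc(N2CCN(C(=O)[C@@H]3CCCN(S(=O)(=O)c4ccc(S(=O)(=O)C(C)C)cc4)C3)CC2)n1` returns > 1 h, which is a limit of the assay rather than a number (the limit of > 1 h in this assay, at which 1 of the 3 values shown sits). Going by the values given here, two measured steps bear on the change in question: a 2.8-fold higher number from compound 1 to compound 3 (0.45 log units; beyond the scatter) and an at least 2.0-fold lower number from compound 2 to compound 3 (0.31 log units; beyond the scatter), both beyond the scatter. Compound 4 `CCN(CC)S(=O)(=O)c1ccc(S(=O)(=O)N2CCC[C@@H](C(=O)N3CCN(c4nc(C(C)C)no4)CC3)C2)cc1` differs from compound 3 by diethylamino in place of isopropylamino on a sulfonyl sulfur. Since the earlier changes at the sulfonyl sulfur each moved the half-life by a modest amount, a modest shift, direction uncertain, is expected for compound 4 as well. Compound 4 is therefore estimated at 0.45 h, with a range from 0.2 h to 1 h. The step expected here, a 1.1-fold lower number from compound 3 to compound 4 (0.04 log units; within the scatter), is accordingly small.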

Compound 4, half-life: 0.128 h
The estimate for compound 4 lay 3.5-fold (0.55 log units) above the measured number; the measured number lies below the stated range.
By their numbers in this assay, from the lowest: compounds 4 and 1 (each within the scatter of the next); then compound 3. At a limit, above all of these: compound 2.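

At this sulfonyl sulfur, the amine matters as well as the sulfamoyl group itself: isopropylsulfamoyl to diethylsulfamoyl gives a 3.8-fold lower number from compound 3 to compound 4 (0.58 log units; beyond the scatter). With diethyl on both, the sulfamoyl and carbamoyl groups do not separate, with a 1.4-fold lower number from compound 1 to compound 4 (0.14 log units; within the scatter). A limit of the assay makes the remaining step a bound only, an at least 7.8-fold lower number from compound 2 to compound 4 (0.89 log units; beyond the scatter): the limit of > 1 h in this assay, at which 1 of the 4 values shown sits.

From the compounds shown here alone, whether ethylamino or an unsubstituted amino group on the sulfonyl sulfur would stand with compound 3 or with compound 4 remains open. So does whether the amide hydrogen of compound 3 matters more than the size of the chains.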